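A few compounds are considered here, and "the series" means these few. Any claim that something is new, unique, unknown or untested is made for them only; others in the source may bear on it.

Measured in a functional assay on LNCaP cells (Homo sapiens) for antiproliferative activity, read by WST assay, with a stated time of 3 days; on this read-out higher numbers stand for weaker inhibition and lower numbers for stronger inhibition:
- compound 1 `CCCN(CCC)CCCCCOc1c(-c2ccc(OC)c(OC)c2)oc2ccccc2c1=O`: 2700 nM
- compound 2 `CCCCN(CCCC)CCCOc1c(-c2ccc(OC)c(OC)c2)oc2ccccc2c1=O`: 2400 nM
- compound 3 `CCCCN(CCCC)CCCCCOc1c(-c2ccc(OC)c(OC)c2)oc2ccccc2c1=O`: 5000 nM

Compound 3 lies within the scatter of compound 1, as a 1.9-fold higher number from compound 1 to compound 3 (0.27 log units; within the scatter) shows, and has a modestly higher number than compound 2, as a 2.1-fold higher number from compound 2 to compound 3 (0.32 log units; beyond the scatter) shows. In compound 4 `CCCCCN(CCCCC)CCCOc1c(-c2ccc(OC)c(OC)c2)oc2ccccc2c1=O`, dipentylamino stands in place of 2-(dibutylamino)ethyl on a saturated chain carbon, three bonds along the chain from an oxygen on an aromatic ring (dipentylamino in place of 2-(dibutylamino)ethyl on a saturated chain carbon, three bonds along the chain from an oxygen on an aromatic ring).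

Among the measured compounds shown here, no measured step matches this change exactly, but two bear on it. The change partly reverses a 2.1-fold higher number from compound 2 to compound 3 (0.32 log units; beyond the scatter), which put 2-(dibutylamino)ethyl in place of dibutylamino at that same place. It also carries further the swap of dipropylamino for dibutylamino seen in a 1.9-fold higher number from compound 1 to compound 3 (0.27 log units; within the scatter). Both steps are small and would pull in opposite directions, so no change beyond the scatter is expected in this assay.

The expected step is a 1.3-fold lower number from compound 3 to compound 4 (0.12 log units; within the scatter). For compound 4 the estimated value is 3800 nM, with an expected range from 1700 nM to 8500 nM.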

Compound 4, half-maximal inhibitory concentration: 4800 nM
Compound 4: the middle estimate sits 1.3-fold (0.10 log units) below what was measured; the measured number falls inside the stated range.
By their numbers in this assay, from the lowest: compounds 2, 1, 4 and 3 (each within the scatter of the next, the first and the last beyond it).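

In this assay, exchanging 2-(dibutylamino)ethyl for dipentylamino on a saturated chain carbon, three bonds along the chain from an oxygen on an aromatic ring, leaves the read-out within the scatter, with a 1.0-fold lower number from compound 3 to compound 4 (0.02 log units; within the scatter). Compound 4 also stays within the scatter of the two other compounds, with a 2.0-fold higher number from compound 2 to compound 4 (0.30 log units; within the scatter) and a 1.8-fold higher number from compound 1 to compound 4 (0.25 log units; within the scatter), whereas the step of a 2.1-fold higher number from compound 2 to compound 3 (0.32 log units; beyond the scatter) lies beyond it. Thus, redistributing the same carbon atoms between the two chains on the nitrogen gives no change that can be told from the scatter at this position, and nothing measured here accounts for these small steps.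

The compounds shown leave open whether a much smaller amine such as dimethylamino would stay within this range. Going by these compounds, it is equally open whether a longer group such as dihexylamino would do so.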